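This account rests on a few compounds, and the source may have more. Where it says the series, first, only, none or still open, it means among the compounds named here.

Measured so far in a functional assay on MGC-803 cells (Homo sapiens) for inhibition, read by MTT assay, with a stated time of 72 h; on this read-out higher numbers stand for weaker inhibition and lower numbers for stronger inhibition:

- compound 1 `CC(C)n1ncc2c(C(=O)Nc3ccccc3)cccc21` gives 38500 nM.
- compound 2 `CC(C)n1ncc2c(C(=O)NC3CCCC3)cccc21` gives only a limit of the assay, > 40000 nM.
- compound 3 `Cc1ccc(-n2cc(CNC(=O)c3cccc4c3cnn4C(C)C)nn2)c(C)c1` gives only a limit of the assay, > 40000 nM.

Within the data shown here, the one step between measured compounds that differ in a single place is an at least 1.0-fold higher number from compound 1 to compound 2 (0.01 log units; that floor lies within the scatter); it concerns the amide-type nitrogen of the shared core, not the group that is varied here, and its floor lies within the scatter. Two of the three values rest at the limit, (the limit of > 40000 nM in this assay, at which 2 of the 3 values shown sit), so the series as shown offers no number below that ceiling apart from compound 1.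

Compound 3 therefore stands at the limit of this assay, with no number of its own; it cannot be ordered against compound 2, and only its place relative to compound 1 is readable.

The step to compound 4 `CC(C)n1ncc2c(C(=O)NCc3cn(-c4cccc(Br)c4)nn3)cccc21` is 3-bromophenyl in place of 2,4-dimethylphenyl on an aromatic nitrogen. No measured step touches this aromatic nitrogen, so nothing among the shown pairs gives a direction or a size for it; the only comparison available, from compound 1 to compound 2, is flat within the scatter. The expectation for this assay is accordingly no step beyond the scatter, with a strong chance that compound 4 again returns only a limit.

Compound 4 is estimated at 40000 nM, with a range of 15000 nM to 120000 nM, which corresponds to an expected step of a number no higher from compound 3 to compound 4 (the limit leaves the size open).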

Compound 4, half-maximal inhibitory concentration: > 40000 nM
Compound 4: no number, only a limit (the forecaster's own chance of this, stated with the estimate: 70%); the middle value lies on the limit itself.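

Compound 3 and compound 4 each return only a limit in this assay, and no step can be read between them: the limit of > 40000 nM in this assay, at which 3 of the 4 values shown sit.

The compounds shown leave open how 3-bromophenyl and 2,4-dimethylphenyl on the aromatic nitrogen compare, and whether any group at that place gives a measurable number in this assay.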